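Swapping the benzyl substituent on a piperidine-linked cinnamamide

This account rests on a few compounds, and the source may have more. Where it says the series, first, only, none or still open, it means among the compounds named here.

Of the compounds shown here, three sharing one core have been tested in an assay on isolated protein for inhibition of Amine oxidase [flavin-containing] A (Homo sapiens), read by fluorescence, with stated times of 15 min and 20 min; a higher number here means a weaker inhibitor, a lower number a stronger inhibitor. Compound 1 `CC(C)(C)c1cc(/C=C/C(=O)NCC2CCN(Cc3ccccc3)CC2)cc(C(C)(C)C)c1O` gives 48400 nM, compound 2 `COc1ccc(CN2CCC(CCNC(=O)/C=C/c3cc(C(C)(C)C)c(O)c(C(C)(C)C)c3)CC2)cc1` gives 72500 nM, and compound 3 `Cc1ccccc1CN1CCC(CCNC(=O)/C=C/c2cc(C(C)(C)C)c(O)c(C(C)(C)C)c2)CC1` gives 69300 nM. Compound 3 stands second highest of these three, within the scatter of both neighbours. Compound 4 `CC(C)(C)c1cc(/C=C/C(=O)NCCC2CCN(Cc3cccc(Cl)c3)CC2)cc(C(C)(C)C)c1O` differs from compound 3 in that (3-chlorophenyl in place of 2-methylphenyl on a saturated chain carbon bound to an amine nitrogen in a ring). Among the compounds with values here, the one comparable step, a 1.0-fold lower number from compound 2 to compound 3 (0.02 log units; within the scatter), shows that changing the aromatic group at this position left this assay unchanged beyond the scatter. On that basis the step from compound 3 to compound 4 is expected to be small, a 1.2-fold lower number from compound 3 to compound 4 (0.06 log units; within the scatter), in no clear direction. Compound 4 is therefore estimated at 60000 nM, with a range from 25000 nM to 140000 nM.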

Compound 4, half-maximal inhibitory concentration: 65100 nM
The estimate for compound 4 lay 1.1-fold (0.04 log units) below the measured number; the measured number falls inside the stated range.
By their numbers in this assay, from the lowest: compounds 1, 4, 3 and 2 (each within the scatter of the next).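

In this assay the 3-chlorophenyl group gives a 1.1-fold lower number from compound 3 to compound 4 (0.03 log units; within the scatter) and a 1.1-fold lower number from compound 2 to compound 4 (0.05 log units; within the scatter) so a ring carrying chlorine sits with the rings carrying methyl and methoxy, and none of the three can be told apart at this position. The flat result now holds across three different substituted benzyl groups rather than two. Nothing available here accounts for this flatness.

From the compounds shown here alone, whether a benzyl ring carrying a carboxylic acid or an amine would shift the number beyond the scatter stays open. So does the effect of a plain phenyl group on the two-carbon-linked series, since only compound 1 has an unsubstituted ring and its linking chain differs as well.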